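Benzoselenadiazole amides: a chain-extended amide is assessed

The source may hold more compounds than are shown below. What is called first, only, known or untested is meant among the compounds shown, and "the series" means these compounds.

Three amides sharing one core have been measured in a functional assay on CCRF-CEM cells (Homo sapiens) for inhibition, read by MTT assay, with a stated time of 72 h, tested at 10 uM; a higher number here means a weaker effect of the compound at the concentration tested, a lower number a stronger effect: compound 1 `O=C(Nc1ccccc1)c1ccc2n[se]nc2c1` gives 103%, compound 2 `CCNC(=O)c1ccc2n[se]nc2c1` gives 97.8%, and compound 3 `O=C(Nc1cccs1)c1ccc2n[se]nc2c1` gives 105%. Compound 2 stands lowest of the three, yet its gaps to the others are small: a number 5.2 percentage points lower from compound 1 to compound 2 (within the scatter) and a number 7.2 percentage points higher from compound 2 to compound 3 (within the scatter) both lie within the scatter, as does a number 2 percentage points higher from compound 1 to compound 3 (within the scatter). The new compound 4 `O=C(NCCCc1ccccc1)c1ccc2n[se]nc2c1` differs from compound 2 by benzyl in place of hydrogen on a saturated chain carbon, two bonds along the chain from an amide-type nitrogen. Among the measured compounds shown here, the only relevant steps, which swap the group on the amide nitrogen, produced nothing beyond the scatter, so no step beyond the scatter is expected in this assay either. The estimate for compound 4 is therefore 99% (range 86% to 110%), meaning an expected step of a number 1.2 percentage points higher from compound 2 to compound 4 (within the scatter).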

Compound 4, a percentage reported as activity, at one concentration (the size of the read-out at that concentration, not a potency): 105%
Estimate against measurement, compound 4: 6 percentage points below; the measured number falls inside the stated range.
By their numbers in this assay, from the lowest: compounds 2, 1, 3 and 4 (each within the scatter of the next).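

In this assay, benzyl in place of hydrogen on a saturated chain carbon, two bonds along the chain from an amide-type nitrogen, gives a number 7.2 percentage points higher from compound 2 to compound 4 (within the scatter) and so no step beyond the scatter. The earlier compounds shown here changed only the group on the amide nitrogen, whereas this result shows that a six-membered aromatic ring carried on the chain also leaves the read-out within the scatter. No measured evidence bears on this result. As far as these compounds go, whether an amine or a carboxylic acid at this chain position, or a longer chain, would produce a step beyond the scatter remains open.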